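Aryl swap on the ring nitrogen of compound 3

The compounds below may be only part of what the source reports. "The series", "measured", "known", "first", "only" and "open" are said of these compounds alone.

Compound 3 `O=C(CCN1CCN(c2ccc(Cl)cc2)CC1)NNc1nncc2ccccc12` gives 700000 nM in a functional assay on thoracic aorta (Rattus norvegicus, strain Wister) (a lower number here means a stronger inhibitor, a higher number a weaker inhibitor), the higher of the two numbers recorded there, though within the scatter of compound 1 `O=C(CN1CCN(c2ccc(Cl)cc2)CC1)NNc1nncc2ccccc12`, which gives 450000 nM. Compound 2 `CCOC(=O)N1CCN(CC(=O)NNc2nncc3ccccc23)CC1` reaches only the limit > 1000000 nM in this assay. Compound 4 `COc1ccccc1N1CCN(CCC(=O)NNc2nncc3ccccc23)CC1` carries 2-methoxyphenyl in place of 4-chlorophenyl on an amine nitrogen in a ring. For the measured compounds named here, the one measured step at this ring nitrogen is an at least 2.2-fold higher number from compound 1 to compound 2 (0.34 log units; beyond the scatter), with a different group entering, and it ran into (the limit of > 1000000 nM in this assay, at which 1 of the 3 values shown sits). That change shares no group with the present one, so it bears on it only loosely; no step beyond the scatter is expected in this assay, with at most a drift toward weaker. Compound 4 is estimated at 800000 nM in this assay, range 350000 nM to 2000000 nM, an expected step of a 1.1-fold higher number from compound 3 to compound 4 (0.06 log units; within the scatter).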

Compound 4, half-maximal inhibitory concentration: 100000 nM
Estimate against measurement, compound 4: 8.0-fold (0.90 log units) above; the measured number lies below the stated range.
By their numbers in this assay, from the lowest: compound 4; then compounds 1 and 3 (each within the scatter of the next). At a limit, above all of these: compound 2.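

At this ring nitrogen, with 2-methoxyphenyl in place of 4-chlorophenyl, this assay shows a 7.0-fold lower number from compound 3 to compound 4 (0.85 log units; beyond the scatter), so the aryl group here clearly shifts the number. This is the only step shown at this nitrogen that runs toward a stronger inhibitor. Nothing measured in the series accounts for the step.

As far as these compounds go, whether an unsubstituted phenyl or a 2-hydroxyphenyl on this nitrogen would fall with compound 3 or with compound 4 stays open. Also open, from the compounds shown here alone, is whether the same swap holds on the chain of compound 1.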